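Cyclohexyl to benzyl on the ring nitrogen: tolerability in cells

The compounds below may be only part of what the source reports. "The series", "measured", "known", "first", "only" and "open" are said of these compounds alone.

Compound 1 `Nc1nc(NC2CCCCC2)c2ncn(/C=C3/CC3(CO)CO)c2n1`: > 20000 nM
Compound 2 `CC(C)CNc1nc(N)nc2c1ncn2/C=C1/CC1(CO)CO`: > 20000 nM

In an ADME assay on BCBL1 cells (Homo sapiens) for cytotoxicity, with a stated time of 7 days (a lower number here means that less compound is tolerated, a higher number that more compound is tolerated), compound 1 gives only a limit of the assay, > 20000 nM, not a number. Compound 3 `Nc1nc(NCc2ccccc2)c2ncn(/C=C3/CC3(CO)CO)c2n1` differs from compound 1 by benzyl in place of cyclohexyl on a nitrogen on an aromatic ring. Going by the values given here, the one measured step, a step that the two limits leave unreadable from compound 1 to compound 2, alters the same nitrogen but its size cannot be read because of the limit of > 20000 nM in this assay, at which 2 of the 2 values shown sit. No direction can therefore be drawn from it. Compound 3 is expected to sit at that same limit, with an estimate of 30000 nM (range 15000 nM to 80000 nM), meaning an expected step that the limit leaves unreadable from compound 1 to compound 3.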

Compound 3, half-maximal cytotoxic concentration: 19900 nM
For compound 3 the middle estimate is 1.5-fold (0.18 log units) above the measured one, and the stated range covers the measured number.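

In this assay, going by these compounds alone, compound 3 gives 19900 nM, the only true number of the three, so this nitrogen can carry a benzyl group and still give a reading inside the range of the assay, with a number no higher from compound 1 to compound 3 (the limit leaves the size open) and a number no higher from compound 2 to compound 3 (the limit leaves the size open). The size of these steps cannot be read, so benzyl cannot be ranked against cyclohexyl or isobutyl, because the other two values are limits: the limit of > 20000 nM in this assay, at which 2 of the 3 values shown sit.

Still open, as far as these compounds go, is whether a longer chain ending in the same phenyl ring would give a lower number. Also open, from the compounds shown here alone, is how an amine or a carboxylic acid on that ring would read.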